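The source may hold more compounds than are shown below. What is called first, only, known or untested is meant among the compounds shown, and "the series" means these compounds.

Measured in an assay on cells for antagonist activity at transient receptor potential cation channel subfamily V member 1 (Homo sapiens), read by FLIPR and calcium flux, with a stated time of 6 min; on this read-out lower numbers stand for stronger inhibition and higher numbers for weaker inhibition:
compound 1 `CCCCOc1nc(C(C)(C)C)ccc1CNC(=O)C(C)c1ccc(NS(C)(=O)=O)c(F)c1`: 0.9 nM
compound 2 `CCCCCCOc1nc(C(C)(C)C)ccc1CNC(=O)C(C)c1ccc(NS(C)(=O)=O)c(F)c1`: 2.7 nM
compound 3 `CCCCOc1cc(C(C)(C)C)ccc1CNC(=O)C(C)c1ccc(NS(C)(=O)=O)c(F)c1`: 1.4 nM

Compound 4 `CCCCCCOc1cc(C(C)(C)C)ccc1CNC(=O)C(C)c1ccc(NS(C)(=O)=O)c(F)c1` is not yet measured. Compound 2 differs from compound 1 by ethyl in place of hydrogen on a saturated chain carbon, four bonds along the chain from an oxygen on an aromatic ring; the step observed was a 3.0-fold higher number from compound 1 to compound 2 (0.48 log units; beyond the scatter). Compound 4 differs from compound 3 by ethyl in place of hydrogen on a saturated chain carbon, four bonds along the chain from an oxygen on an aromatic ring, the same change at the same place. The difference between the core of compound 1 and the core of compound 3 is not broken down here; in this assay the values of compound 1 and compound 3 lie within the scatter of each other. Among the measured compounds shown here, for compound 4 the expected step is a 2.9-fold higher number from compound 3 to compound 4 (0.46 log units; beyond the scatter), resting on that single earlier step with no second example of the change measured. Compound 4 is therefore estimated at 4 nM, expected to fall between 1.5 nM and 10 nM.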

Compound 4, inhibition constant: 0.5 nM
The estimate for compound 4 lay 8.0-fold (0.90 log units) above the measured number; the measured number lies below the stated range.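

In this assay, ethyl in place of hydrogen on this chain carbon gives a 2.8-fold lower number from compound 3 to compound 4 (0.45 log units; beyond the scatter), opposite in direction to the step on the core of compound 1, so the change does not carry over between these two cores: the same change on two cores in this assay, a 3.0-fold higher number (0.48 log units; beyond the scatter) from compound 1 to compound 2 and a 2.8-fold lower number (0.45 log units; beyond the scatter) from compound 3 to compound 4, 8.4-fold (0.92 log units) apart, beyond the scatter of two such steps

A step read on one of these cores is therefore no guide to the same change on the other. Among the compounds shown here, with only one pair on each core, this sets no rule for other cores or chains, and the data do not show what in the cores lies behind the difference.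

From the compounds shown here alone, it remains open how a still longer chain would behave on each core. Going by these compounds, a chain ending in an amine or a carboxylic acid is equally open.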